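A Cyclopropyl Amine in Place of Pyridin-4-yl

The compounds below may be only part of what the source reports. "The series", "measured", "known", "first", "only" and "open" are said of these compounds alone.

Measured so far in a functional assay on SK-OV-3 cells (Homo sapiens) for inhibition, read by CCK-8 assay, with a stated time of 70 h; on this read-out higher numbers stand for weaker inhibition and lower numbers for stronger inhibition:
Compound 1 `c1ccc(COc2ccc(OCCOCCNc3ccncc3)cc2)cc1`: 20600 nM
Compound 2 `c1ccc(COc2ccc(COc3ccc(OCCOCCNC4CCCCC4)cc3)cc2)cc1`: 8080 nM
Compound 3 `Nc1ccccc1COc1ccc(OCCOCCNC2CCCC2)cc1`: 14000 nM

Compound 1 holds the highest of these three numbers, although compound 3 lies within the scatter of it. Only compound 2 lies beyond the scatter, with a lower number. Compound 4 `c1ccc(COc2ccc(OCCOCCNC3CC3)cc2)cc1` carries cyclopropyl in place of pyridin-4-yl on an amine nitrogen. Among the measured compounds shown here, no two measured compounds differ in one place, so this change has no direct precedent. In this assay a small move towards a lower number is expected, none beyond the scatter, and the estimated step is a 1.5-fold lower number from compound 1 to compound 4 (0.17 log units; within the scatter). For compound 4 the estimated value is 14000 nM (expected range 6500 nM to 30000 nM).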

Compound 4, half-maximal inhibitory concentration: 47200 nM
Compound 4: middle estimate off by 3.4-fold (0.53 log units), on the low side; measured number outside the range, above it.
By their numbers in this assay, from the lowest: compounds 2, 3 and 1 (each within the scatter of the next, the first and the last beyond it); then compound 4.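

In this assay, cyclopropyl in place of pyridin-4-yl on an amine nitrogen gives a 2.3-fold higher number from compound 1 to compound 4 (0.36 log units; beyond the scatter). Among the compounds shown here, this is the first comparison here between compounds that differ in one place, and it shows that this position is sensitive to the change, which weakens inhibition modestly but beyond the scatter. Nothing available gives a reason for this loss. Going by these compounds, it remains open whether phenyl on the same nitrogen, or a longer carbon chain in place of cyclopropyl, would stay within the scatter of compound 1.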